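This account rests on a few compounds, and the source may have more. Where it says the series, first, only, none or still open, it means among the compounds named here.

Three related compounds have so far been tested in a functional assay on HCT-116 cells (Homo sapiens) for cytotoxicity, read by fluorescence and resazurin assay, with a stated time of 48 h; a higher number here means a weaker inhibitor, a lower number a stronger inhibitor. Compound 1 `COc1cc(/C=C/c2cc(/C=C/c3cc(OC)c(OC)c(OC)c3)nc(OCCCCBr)n2)cc(OC)c1OC` and compound 3 `COc1cc(/C=C/c2cc(/C=C/c3cc(OC)c(OC)c(OC)c3)nc(OCCCCCBr)n2)cc(OC)c1OC` share one core, while compound 2 `COc1ccc(/C=C/c2cc(/C=C/c3ccc(OC)c(OC)c3)nc(OCCCCCCBr)n2)cc1OC` is built on another; the difference between the two cores is not broken down here. In this assay compound 1 gives > 20000 nM, and this value is a limit of the assay rather than a number. In this assay compound 3 gives > 20000 nM, again a limit of the assay. In this assay compound 2 gives > 20000 nM, also a limit of the assay.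

The change from compound 3 to compound 1 is bromo in place of bromomethyl on a saturated chain carbon, four bonds along the chain from an oxygen on an aromatic ring. Because the limit of > 20000 nM in this assay, at which 3 of the 3 values shown sit, is where all three measured values sit, the step that the two limits leave unreadable from compound 3 to compound 1 cannot be sized in either direction.

Compound 4 `COc1ccc(/C=C/c2cc(/C=C/c3ccc(OC)c(OC)c3)nc(OCCCCCBr)n2)cc1OC` has not yet been measured. It differs from compound 2 by bromo in place of bromomethyl on a saturated chain carbon, five bonds along the chain from an oxygen on an aromatic ring, the same kind of change as that from compound 3 to compound 1, though here the saturated chain carbon is five bonds along the chain from an oxygen on an aromatic ring rather than four. The step expected in this assay is a step that the limit leaves unreadable from compound 2 to compound 4, an expectation that rests on (the limit of > 20000 nM in this assay, at which 3 of the 3 values shown sit), the same limit at which every measured value here sits. Compound 4 is therefore estimated at 30000 nM, with a range from 12000 nM to 100000 nM, and the assay is expected most likely to report only a limit once more.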

Compound 4, half-maximal inhibitory concentration: > 20000 nM
Compound 4 was reported as a limit; the forecaster's own chance of this, stated with the estimate: 85%; the middle value does not contradict the limit.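

No new step can be read, since compound 2 and compound 4 are both reported only as a limit and the size of the change between them stays unknown because of where they sit: the limit of > 20000 nM in this assay, at which 4 of the 4 values shown sit.

The compounds shown leave open whether any chain length on either core gives a true measured value in this assay.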